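Pyrazole carboxamide series: methyl removal on the pyrazole ring

The source may hold more compounds than are shown below. What is called first, only, known or untested is meant among the compounds shown, and "the series" means these compounds.

Two cores are compared in an assay on membranes from brain for binding affinity to Fatty-acid amide hydrolase 1 (Mus musculus), read by fluorescence, with stated times of 1 h and 30 min; a higher number here means a weaker inhibitor, a lower number a stronger inhibitor. Compound 1 `Cc1cnn(C(=O)N2CCCN(Cc3ccc(OCc4ccccc4)cc3)CC2)c1` gives 560 nM, and compound 2 `O=C(N1CCCN(Cc2ccc(OCc3ccccc3)cc2)CC1)n1cccn1` gives 450 nM. The change between them, (hydrogen in place of methyl on an aromatic carbon), produced a 1.2-fold lower number from compound 1 to compound 2 (0.09 log units; within the scatter); the two values show no ordering.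

Compound 3 `Cc1cnn(C(=O)N(C)CCN(C)Cc2cccc(OCc3ccccc3)c2)c1` carries an open-chain core in place of the ring of compound 1. In this assay compound 3 gives 9000 nM. How the two cores differ is not broken down here; the values of compound 1 and compound 3 show a gap well beyond the scatter.

Compound 4 `CN(CCN(C)C(=O)n1cccn1)Cc1cccc(OCc2ccccc2)c1` is not yet measured. It differs from compound 3 by hydrogen in place of methyl on an aromatic carbon, and the place of this change is the same, word for word, as the change from compound 1 to compound 2. The expectation for compound 4 therefore rests on the step from compound 1 to compound 2, which stayed within the scatter: the expected step for compound 4 is a 1.2-fold lower number from compound 3 to compound 4 (0.08 log units; within the scatter). On that basis compound 4 is estimated at 7500 nM in this assay, with a likely range of 3000 nM to 20000 nM.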

Compound 4, half-maximal inhibitory concentration: 3000 nM
Compound 4: middle estimate off by 2.5-fold (0.40 log units), on the high side, and the stated range covers the measured number.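

In this assay, replacing 4-methyl-1H-pyrazol-1-yl with 1H-pyrazol-1-yl on the open-chain core gives a 3.0-fold lower number from compound 3 to compound 4 (0.48 log units; beyond the scatter) and so does not cost affinity on this core, while the same change on the core of compound 1 stayed within the scatter. Set side by side, the two steps do not separate: the same change on two cores in this assay, a 1.2-fold lower number (0.09 log units; within the scatter) from compound 1 to compound 2 and a 3.0-fold lower number (0.48 log units; beyond the scatter) from compound 3 to compound 4, 2.4-fold (0.38 log units) apart, within the scatter of two such steps. The change therefore carries across these two cores without a demonstrable difference in step size, but one pair on each core shows neither that the step size is fixed nor that the open-chain core responds more strongly.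

The compounds shown leave open how ethyl, chlorine or a nitrile in place of the methyl would behave on either core. They also leave open whether the step between these two pyrazole groups would hold on a third core, such as one carrying an amine or a carboxylic acid on the benzyloxy end.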